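The source may hold more compounds than are shown below. What is called first, only, known or untested is meant among the compounds shown, and "the series" means these compounds.

Compound 1 `COc1cccc(-c2ccc3c(NC(=O)c4ccc(N5CCN(C)CC5)cc4F)n[nH]c3c2)c1F` and compound 2 `CCN1CCN(c2ccc(C(=O)Nc3n[nH]c4cc(-c5c(F)cc(F)c(OC)c5F)ccc34)cc2)CC1` share one core. In a functional assay on SNU-16 cells (Homo sapiens) for antiproliferative activity, read by CCK-8 assay, with a stated time of 72 h (a higher number here means a weaker inhibitor, a lower number a stronger inhibitor), compound 1 reaches only the limit of the assay, > 1000 nM, and not a number. Compound 2 likewise gives only a limit, > 1000 nM. Both values thus sit at the limit of > 1000 nM in this assay, at which 2 of the 2 values shown sit. Compound 3 `CCN1CCN(c2ccc(C(=O)Nc3n[nH]c4cc(-c5c(F)ccc(OC)c5F)ccc34)cc2)CC1` differs from compound 2 by a single change, (hydrogen in place of fluoro on an aromatic carbon), turning the 2,4,6-trifluoro-3-methoxyphenyl into a 2,6-difluoro-3-methoxyphenyl. Going by the values given here, no measured step guides this, so the expected step in this assay is small and of no fixed direction. Compound 3 is estimated at 1500 nM, ranging from 500 nM to 5000 nM. The expected step, a step that the limit leaves unreadable from compound 2 to compound 3, stays within the usual scatter.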

Compound 3, half-maximal inhibitory concentration: 77.4 nM
Estimate against measurement, compound 3: 19-fold (1.29 log units) above, and the stated range ends above it.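

In this assay this position proves sensitive: hydrogen in place of fluoro on the aromatic carbon ortho to a methoxy group gives an at least 12-fold lower number from compound 2 to compound 3 (1.11 log units; beyond the scatter) and brings the shared core from a limit to a readable number. The full size of this step stays unknown because compound 2 gives only a limit: the limit of > 1000 nM in this assay, at which 2 of the 3 values shown sit.

On these data alone, whether chlorine, a methyl group or an amine on this carbon would act like hydrogen remains open. So does the part played by the two remaining fluoro groups of compound 3.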